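Dropping the bromine from compound 2

The source may hold more compounds than are shown below. What is called first, only, known or untested is meant among the compounds shown, and "the series" means these compounds.

For the measured compounds named here, compound 2 `O=C(Nc1ccc(-c2cnc3cc(Br)ccn23)cc1)c1ccc([N+](=O)[O-])o1` is one of two compounds measured in a functional assay on MGC-803 cells (Homo sapiens) for antiproliferative activity, read by CCK-8 assay, with a stated time of 72 h; a higher number here means a weaker inhibitor, a lower number a stronger inhibitor. In this assay compound 2 gives 750 nM, the lower of the two numbers. The other compound, compound 1 `CC1(O)CCN(c2ccn3c(-c4ccc(NC(=O)c5ccc([N+](=O)[O-])o5)cc4)cnc3c2)CC1`, gives 3100 nM in this assay. Going by the values given here, the single measured step, a 4.1-fold lower number from compound 1 to compound 2 (0.62 log units; beyond the scatter), came from putting bromo in place of 4-hydroxy-4-methylpiperidin-1-yl on an aromatic carbon, so the carbon that carries the bromine is the one place where a change has been tested.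

Compound 3 `O=C(Nc1ccc(-c2cnc3ccccn23)cc1)c1ccc([N+](=O)[O-])o1` differs from compound 2 by hydrogen in place of bromo on an aromatic carbon. Among the compounds with values here, this change sits on the same carbon as the measured step, which is therefore the only guide; that step shows a modest shift when the group on this carbon was exchanged. Within the data shown here, no measured pair compares bromo with hydrogen directly, so the direction is uncertain. The step is expected to be a 2.0-fold higher number from compound 2 to compound 3 (0.30 log units; within the scatter), a small rise, at the edge of the scatter. For compound 3 the expected value in this assay is 1500 nM, with a range from 500 nM to 4500 nM.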

Compound 3, half-maximal inhibitory concentration: 590 nM
Compound 3: middle estimate off by 2.5-fold (0.41 log units), on the high side, within the range that was stated.
By their numbers in this assay, from the lowest: compounds 3 and 2 (each within the scatter of the next); then compound 1.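

In this assay removing the bromine gives a 1.3-fold lower number from compound 2 to compound 3 (0.10 log units; within the scatter) and so bromo and hydrogen on this carbon cannot be told apart by this read-out, which means the bromine is not needed for a number of this size. The larger gap now appears from two sides, as a 5.3-fold lower number from compound 1 to compound 3 (0.72 log units; beyond the scatter) stands alongside a 4.1-fold lower number from compound 1 to compound 2 (0.62 log units; beyond the scatter) and so, among these three compounds, only compound 1 with its 4-hydroxy-4-methylpiperidin-1-yl group lies apart from the other two. Nothing measured here explains why the numbers fall this way.

Going by these compounds, what remains open is whether the higher number of compound 1 belongs to the piperidine ring as such or to its hydroxy and methyl groups, a question that a plain piperidine on the same carbon would help to separate. Also open, on these data alone, is how a different small group on this carbon, such as an amine, a methoxy group or a carboxylic acid, would compare with hydrogen and bromo, and whether any group placed here can bring the number below those of compound 2 and compound 3.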